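This account rests on a few compounds, and the source may have more. Where it says the series, first, only, none or still open, it means among the compounds named here.

Compound 3 (`O=C(O)c1ccc(-c2cnc(C(=O)CCc3ccc(Oc4ccccc4)cc3)o2)nc1`) carries the highest number of the three measured compounds in an assay for inhibition of Fatty-acid amide hydrolase 1 (Rattus norvegicus) (a higher number here means a weaker inhibitor, a lower number a stronger inhibitor), at 33 nM; compound 2 (`O=C(O)c1ccc(-c2cnc(C(=O)CCc3ccc(-c4ccccc4)cc3)o2)nc1`) is nearest with 14 nM, and compound 1 (`CS(=O)(=O)c1cnc(C(=O)CCc2ccc(-c3ccccc3)cc2)o1`) furthest with 1.2 nM. Compound 4 (`N#Cc1cnc(C(=O)CCc2ccc(Oc3ccccc3)cc2)o1`) differs from compound 3 in one place: cyano in place of 5-carboxypyridin-2-yl on an aromatic carbon. Within the data shown here, no measured step makes this exact swap. The closest guide runs the other way: a 12-fold higher number from compound 1 to compound 2 (1.07 log units; beyond the scatter), where a small group on an aromatic carbon of a five-membered aromatic ring with 1 nitrogen and 1 oxygen gave way to the 5-carboxypyridin-2-yl group. Compound 4 reverses that kind of change, trading the larger group for cyano, a group of 2 heavy atoms. The other measured step, a 2.4-fold higher number from compound 2 to compound 3 (0.37 log units; beyond the scatter), alters a different part of the structure and does not speak to this swap. If the reversal of the earlier step holds, a large downward step is expected, an 11-fold lower number from compound 3 to compound 4 (1.04 log units; beyond the scatter). Compound 4 is therefore estimated at 3 nM, with a range of 0.8 nM to 12 nM.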

Compound 4, inhibition constant: 0.8 nM
Estimate against measurement, compound 4: 3.8-fold (0.57 log units) above; low and high end bracket the measured number.
By their numbers in this assay, from the lowest: compounds 4 and 1 (each within the scatter of the next); then compound 2; then compound 3.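

In this assay, the step from the large ring-bearing group to cyano, on the aromatic carbon next to the ring oxygen, is a 41-fold lower number from compound 3 to compound 4 (1.62 log units; beyond the scatter). The earlier compounds shown here showed the 5-carboxypyridin-2-yl group with a higher number than methylsulfonyl only on the phenyl-bearing tail; this result shows the same direction against a different small group, cyano, on the phenoxy-bearing tail. Nothing measured here explains the change.

The 5-carboxypyridin-2-yl group brings both a ring and a carboxylic acid, so these compounds cannot tell which of the two goes with the higher number. A plain pyridin-2-yl group, or a carboxylic acid placed directly on this carbon, would help to separate them.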